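A Polar Side Chain Replaces Benzyl in Compound 3

The source may report more compounds than this note shows. Statements on the series, on what has been measured and on what is new or still open speak of the compounds shown alone.

Of the compounds shown here, two have so far been measured in a functional assay on EL4 cells (Mus musculus) for inhibition, tested at 100 uM; on this read-out lower numbers stand for less inhibition and higher numbers for more inhibition at the one concentration tested (going by the name of the read-out). Compound 1 `CN(C)c1nccc2c1ncn2[C@H]1C[C@H](O)[C@@H](CO)O1` returns only a limit of the assay: in this assay compound 1 gives < 5%, which is a limit and not a number. Among the measured compounds shown here, compound 2 `OC[C@H]1OC(n2cnc3c(NCc4ccccc4)nccc32)[C@H](O)[C@@H]1O` is the one compound with an actual figure: in this assay compound 2 gives 5%. Compound 2 therefore stands as the only number shown, the remaining value being a limit (the limit of < 5% in this assay, at which 1 of the 2 values shown sits), and both readings mark very little inhibition at the single concentration tested.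

Compound 3 `OCCNc1nccc2c1ncn2C1O[C@H](CO)[C@@H](O)[C@H]1O` has not yet been measured. It differs from compound 2 in one place: hydroxymethyl in place of phenyl on a saturated chain carbon bound to a nitrogen on an aromatic ring. For the measured compounds named here, no step between measured compounds has been worked out, so there is no measured precedent for the effect of this exchange. The account expects the step from compound 2 to compound 3 to be a number 1 percentage points lower from compound 2 to compound 3 (within the scatter), which is none beyond the usual scatter of this kind of measurement. Compound 3 is accordingly estimated to give 4% in this assay, with a range from 0% to 12%, and there is a fair chance the assay will again report only a limit.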

Compound 3, a percentage reported as inhibition, at one concentration (the size of the read-out at that concentration, not a potency): 6%
Compound 3: the middle estimate sits 2 percentage points below what was measured, within the range that was stated.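

Among the compounds shown here, the exchange of phenyl for hydroxymethyl, on a saturated chain carbon bound to a nitrogen on an aromatic ring, gives the first step that can be read in this assay, and it comes out as a number 1 percentage points higher from compound 2 to compound 3 (within the scatter). At this position benzyl and 2-hydroxyethyl therefore cannot be told apart on this read-out: the aromatic ring of carbon leaves, a hydrogen-bond donor and a hydrogen-bond acceptor enter, and the reading shows no change beyond the scatter at the one concentration tested. The readings all remain at the low end of the read-out, and a limit stands among them: the limit of < 5% in this assay, at which 1 of the 3 values shown sits.

Whether any other group at this place would give more inhibition stays open, since an amine, a carboxylic acid or a longer chain ending in hydroxyl is not among the compounds shown. As far as these compounds go, it also stays open whether benzyl and 2-hydroxyethyl would still read alike at another concentration or in a read-out of potency.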